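Swapping a sulfur-containing ring for an oxygen one

The source may report more compounds than this note shows. Statements on the series, on what has been measured and on what is new or still open speak of the compounds shown alone.

Measured compounds:
- compound 1, `COc1ccc(C2=NN(c3ccccc3)C(c3ccc(C)cc3)C2S(=O)(=O)CC2=NCCS2)cc1`, 43.9%
- compound 2, `O=S(=O)(CC1=NCCS1)c1c(-c2ccc(Cl)cc2)nn(-c2ccccc2)c1-c1ccc(Cl)cc1`, "not active" (no number reported)
- compound 3, `O=S(=O)(CC1=NCCO1)c1c(-c2ccccc2)noc1-c1ccccc1`, 58.1%

All three were tested in a functional assay, tested at 75 ug/mL; on this read-out higher numbers stand for a stronger effect at the one concentration tested and lower numbers for a weaker effect. Compound 1 gives 43.9% and compound 3 gives 58.1% in this assay, both clearly measurable effects. Compound 2 stands apart: in this assay compound 2 gives "not active" (no number reported), so there is no single number to place it on the same scale, and it can only be taken as weaker than the two compounds with reported values.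

The unmeasured compound 4, `O=S(=O)(CC1=NCCO1)c1c(-c2ccc(Cl)cc2)nn(-c2ccccc2)c1-c1ccc(Cl)cc1`, keeps the whole of compound 2 except one group. The change is a group of 5 heavy atoms (3 carbon, 1 nitrogen, 1 oxygen; one five-membered non-aromatic ring with 2 hetero atoms) in place of a group of 5 heavy atoms (3 carbon, 1 nitrogen, 1 sulfur; one five-membered non-aromatic ring with 2 hetero atoms), on a saturated chain carbon bound to a sulfonyl sulfur. Among the measured compounds shown here, no pair of measured compounds differs in exactly this way, so no measured step tells the size of its effect. Compound 3 carries the same oxygen-containing ring on a different core and gives a moderate read-out, which leaves open a modest gain over compound 2, but the starting point is a compound with no reported activity.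

Compound 4 is therefore expected to show only a weak effect in this assay, estimated at 20% with a likely range from 0% to 45%.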

Compound 4, a percentage reported as activity, at one concentration (the size of the read-out at that concentration, not a potency): "not active" (no number reported)
No number was reported for compound 4, and the estimate cannot be compared.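

Compound 2 and compound 4 are both reported as "not active" in this assay, with no number for either, so no step can be read for the swap from the sulfur-containing ring to the oxygen-containing one. No evidence shown bears on this result. The compounds shown leave open whether this swap changes the read-out on a core that gives a reported number.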